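This account rests on a few compounds, and the source may have more. Where it says the series, first, only, none or still open, it means among the compounds named here.

For the measured compounds named here, in a functional assay on HL-60 cells (Homo sapiens) for cytotoxicity, read by WST assay, with a stated time of 48 h (on this read-out higher numbers stand for an effect only at larger amounts of compound and lower numbers for an effect already at smaller amounts), compound 1 (`O=C1OC[C@H](Cc2ccccc2)[C@H]1Cc1cccc(OC(F)(F)F)c1`) gives 34000 nM and compound 2 (`COCOc1cccc(C[C@H]2C(=O)OC[C@@H]2Cc2ccccc2)c1`) gives 80000 nM as the higher of the two numbers measured so far. These two compounds differ only in the group on an oxygen on an aromatic ring, and the measured step is a 2.4-fold higher number from compound 1 to compound 2 (0.37 log units; beyond the scatter) for methoxymethyl in place of trifluoromethyl. Compound 3 (`CCCCOc1cccc(C[C@H]2C(=O)OC[C@@H]2Cc2ccccc2)c1`) changes the same group once more, and its difference from compound 2 is propyl in place of methoxy on a saturated chain carbon bound to an oxygen on an aromatic ring so that butoxy stands where methoxymethoxy stood. Going by the values given here, that single modest step is the only measurement bearing on this place, and no compound with a plain butyl chain has a number yet. Among the compounds with values here, compound 2 holds the higher number and compound 1 at 34000 nM shows the one other group measured there lying lower, so a modest move downward is expected rather than a large one in either direction. The expected change is a 2.0-fold lower number from compound 2 to compound 3 (0.30 log units; within the scatter) with little confidence in its direction. For compound 3 the estimate is 40000 nM with an expected range from 15000 nM to 100000 nM in this assay once measured.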

Compound 3, half-maximal effective concentration: 26000 nM
Compound 3: the middle estimate sits 1.5-fold (0.19 log units) above what was measured; low and high end bracket the measured number.
By their numbers in this assay, from the lowest: compounds 3 and 1 (each within the scatter of the next); then compound 2.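

In this assay, butyl on this oxygen gives the step of a 3.1-fold lower number from compound 2 to compound 3 (0.49 log units; beyond the scatter). The gap between compound 1 and compound 2 was therefore not a one-off: a second group on this oxygen, butyl, also gives a number beyond the scatter of compound 2. The step of a 1.3-fold lower number from compound 1 to compound 3 (0.12 log units; within the scatter) lies within the scatter, so butyl and trifluoromethyl cannot be told apart here, even though one is a plain saturated chain and the other is fluorinated. Compound 2, whose methoxymethyl group is the only one of the three with an oxygen in the chain, now stands apart from both others, although a single compound cannot show that this oxygen is what matters, and nothing available explains the difference.

The compounds shown leave open whether a longer chain such as hexyl, or a shorter one such as ethyl, would move the number beyond that of compound 3 and compound 1. They also leave open what a chain ending in an amine or a carboxylic acid would do at this oxygen, and whether a free hydroxyl in place of the whole group would keep any effect.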